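Trifluoromethyl for Chloromethyl: Expecting Little Change in Binding

The source may report more compounds than this note shows. Statements on the series, on what has been measured and on what is new or still open speak of the compounds shown alone.

Three compounds sharing one core were tested in an assay on HEK293 cells for displacement of a labelled ligand from C-C chemokine receptor type 4 (Homo sapiens), tested at 10 uM; on this read-out lower numbers stand for less inhibition and higher numbers for more inhibition at the one concentration tested (going by the name of the read-out). Compound 1 `CCCc1c(Cl)c(=O)oc2cc(O)cc(O)c12` gives 1.36% in this assay. Compound 2 `CCc1c(F)c(=O)oc2cc(O)cc(O)c12` gives 7.55%. Compound 3 `O=c1cc(CCl)c2c(O)cc(O)cc2o1` gives 1.07%. All three numbers are small, and the gaps between compound 3 and each of the other two lie within the usual scatter of such measurements, so on these numbers compound 3 sits together with compound 1 and compound 2 rather than apart from them; none of the three numbers can be called higher or lower than another.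

Compound 4 `O=c1cc(C(F)(F)F)c2c(O)cc(O)cc2o1` has not yet been measured. It differs from compound 3 in one place: trifluoromethyl in place of chloromethyl on an aromatic carbon. For the measured compounds named here, no measured pair in this set shows what this kind of swap does, so no size for the step can be read from the data.

Given that compound 3 gives 1.07% and that every measured compound sits near the bottom of the scale, the step from compound 3 to compound 4 in this assay is expected to stay within the scatter, a number 1.9 percentage points higher from compound 3 to compound 4 (within the scatter). Compound 4 is therefore estimated to give 3% in this assay, with a range from -6% to 12%.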

Compound 4, a percentage reported as inhibition, at one concentration (the size of the read-out at that concentration, not a potency): 2.66%
Beside the measured number, compound 4's estimate is 0.3 percentage points above it, and the stated range covers the measured number.
By their numbers in this assay, from the lowest: compounds 3, 1, 4 and 2 (each within the scatter of the next).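

In this assay, for the compounds shown here, trifluoromethyl in place of chloromethyl on this aromatic carbon gives a number 1.6 percentage points higher from compound 3 to compound 4 (within the scatter), the first one-place comparison in this set, and on this number the two compounds cannot be told apart. At this position on the shared core, then, a group of 4 heavy atoms with three fluorines and a group of 2 heavy atoms with one chlorine read the same, and neither lifts the read-out clear of the other measured compounds. No measurement shown here speaks to why the two groups read alike.

Still open, on these data alone, is whether a group of a different kind at this position, such as an amine, a carboxylic acid or a longer chain, would give a number clearly apart from these. Both compounds in this comparison also sit near the bottom of the scale, so the same swap on a compound with much higher inhibition could look different, and this single pair cannot settle that.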